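The source may report more compounds than this note shows. Statements on the series, on what has been measured and on what is new or still open speak of the compounds shown alone.

Compound 1 `COc1cc2c(cc1OC)CN(S(=O)(=O)c1ccc(-n3cc(COc4ccccc4C(C)=O)nn3)cc1)CC2` carries a 2-acetylphenyl group on the oxygen on a saturated carbon of the shared core. In a functional assay on HuCC-A1 cells (Homo sapiens) for cytotoxicity, read by MTT assay, with a stated time of 48 h (on this read-out higher numbers stand for weaker inhibition and lower numbers for stronger inhibition), compound 1 gives > 50 ug/mL, which is a limit of the assay rather than a number. Compound 2 `COc1cc2c(cc1OC)CN(S(=O)(=O)c1ccc(-n3cc(COc4ccc([N+](=O)[O-])cc4)nn3)cc1)CC2` bears 4-nitrophenyl in place of 2-acetylphenyl at the same oxygen. In this assay compound 2 gives > 50 ug/mL, again a limit. The step that the two limits leave unreadable from compound 1 to compound 2 therefore cannot be read, and compound 2 stands only at the limit of > 50 ug/mL in this assay, at which 2 of the 2 values shown sit, with no numerical value to place it. Compound 3 `COc1cc2c(cc1OC)CN(S(=O)(=O)c1ccc(-n3cc(COc4ccc5ccccc5c4)nn3)cc1)CC2` differs from compound 2 by naphthalen-2-yl in place of 4-nitrophenyl on an oxygen on a saturated carbon. Going by the values given here, no measured step bears on this change, since both values so far are limits, so no size or direction of a step in this assay can be drawn from them. Compound 3 is expected at 60 ug/mL, within 30 ug/mL to 150 ug/mL. The step that the limit leaves unreadable from compound 2 to compound 3 is thus estimated to stay within the scatter.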

Compound 3, half-maximal inhibitory concentration: > 50 ug/mL
Compound 3: no number, only a limit; the forecaster's own chance of this, stated with the estimate: 70%; the middle value lies beyond the limit too.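

Going by these compounds alone, no step among compound 1, compound 2 and compound 3 can be read, since all three values are limits and not numbers: the limit of > 50 ug/mL in this assay, at which 3 of the 3 values shown sit.

The compounds shown leave open how far these three lie from one another, and whether any group on this oxygen gives a readable number.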